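Chain length on the aryl ether of compound 3 extended

The compounds below may be only part of what the source reports. "The series", "measured", "known", "first", "only" and "open" are said of these compounds alone.

Measured compounds:
Compound 1, `NC(=O)COc1cc(CNc2nc3c(N)ncnc3n2[C@@H]2O[C@H](CO)[C@@H](O)[C@H]2O)ccc1-c1ccccc1`: > 100000 nM
Compound 2, `Nc1ncnc2c1nc(NCc1ccc(-c3ccccc3)c(OCCO)c1)n2[C@@H]1O[C@H](CO)[C@@H](O)[C@H]1O`: > 100000 nM
Compound 3, `Nc1ncnc2c1nc(NCc1ccc(-c3ccccc3)c(OCCCCO)c1)n2[C@@H]1O[C@H](CO)[C@@H](O)[C@H]1O`: 38000 nM

Three compounds sharing one core were tested in an assay on COS-7 cells for inhibition of sodium/nucleoside cotransporter 2 (Rattus norvegicus), read by scintillation counting; on this read-out lower numbers stand for stronger inhibition and higher numbers for weaker inhibition. For compound 1 this assay gives only a limit, > 100000 nM. For compound 2 it likewise gives only a limit, > 100000 nM. Compound 3 is the only one of the three with a number, 38000 nM, which places it apart from the other two; that both sit at the limit of > 100000 nM in this assay, at which 2 of the 3 values shown sit, is the whole of the evidence on the measured steps. The step of an at least 2.6-fold lower number from compound 2 to compound 3 (0.42 log units; beyond the scatter) and the step of an at least 2.6-fold lower number from compound 1 to compound 3 (0.42 log units; beyond the scatter) both run downward, and the step that the two limits leave unreadable from compound 1 to compound 2 cannot be read.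

Compound 4, `Nc1ncnc2c1nc(NCc1ccc(-c3ccccc3)c(OCCCCCO)c1)n2[C@@H]1O[C@H](CO)[C@@H](O)[C@H]1O`, has not yet been measured. It differs from compound 3 by hydroxymethyl in place of hydroxy on a saturated chain carbon, four bonds along the chain from an oxygen on an aromatic ring. Within the data shown here, the one readable change of this kind, from compound 2 to compound 3, lengthened the same chain and lowered the number in this assay by at least a modest amount. Among the measured compounds shown here, on that basis compound 4 is expected to give a lower number again, with the step of a 1.9-fold lower number from compound 3 to compound 4 (0.28 log units; within the scatter) estimated as modest and of the same direction, though only one prior step of this kind supports it. The estimate for compound 4 in this assay is 20000 nM, between 7000 nM and 60000 nM.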

Compound 4, half-maximal inhibitory concentration: 60000 nM
Beside the measured number, compound 4's estimate is 3.0-fold (0.48 log units) below it; measured number inside the range.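

In this assay, the step that turns the 3-hydroxypropyl group of compound 3 into the 4-hydroxybutyl group of compound 4 reads as a 1.6-fold higher number from compound 3 to compound 4 (0.20 log units; within the scatter), so the two chains cannot be told apart here, and the lowering of the number seen when the chain grew from compound 2 to compound 3 finds no readable continuation at this position. The other two new steps are an at least 1.6-fold lower number from compound 2 to compound 4 (0.22 log units; that floor lies within the scatter) and an at least 1.6-fold lower number from compound 1 to compound 4 (0.22 log units; that floor lies within the scatter), so neither shows that the 4-hydroxybutyl chain stands apart from the shorter hydroxyalkyl chain or the carbamoyl group. Both of those steps are floors and not measured sizes, set by a limit rather than a number: the limit of > 100000 nM in this assay, at which 2 of the 4 values shown sit.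

What the compounds shown leave open is whether a longer chain carrying the same hydroxy group would give a number beyond the scatter from those of compound 3 and compound 4. They also leave open whether the hydroxy group itself matters, as nothing here shows a plain butyl chain, or an amine or a carboxylic acid in its place.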